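A few compounds are considered here, and "the series" means these few. Any claim that something is new, unique, unknown or untested is made for them only; others in the source may bear on it.

Measured so far:
Compound 1 `CN(C)CCCNc1nc(-c2ccc(NC(=O)Nc3ccccc3Cl)cc2)nc2c(Cl)c(Cl)sc12`: 490 nM
Compound 2 `CCN(CC)CCNc1nc(-c2ccc(NC(=O)Nc3ccc(F)cc3)cc2)nc2c(Cl)c(Cl)sc12`: 500 nM

Both were tested in a functional assay on NCI-H460 cells (Homo sapiens) for cytotoxicity, read by MTT assay, with a stated time of 72 h; on this read-out lower numbers stand for stronger inhibition and higher numbers for weaker inhibition. Compound 1 gives 490 nM, and compound 2 gives 500 nM. Compound 2 has the higher of the two numbers, but its gap to compound 1 lies within the scatter, so the two read alike.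

Compound 3 `CCN(CC)CCNc1nc(-c2ccc(NC(=O)Nc3ccccc3Cl)cc2)nc2c(Cl)c(Cl)sc12` has not yet been measured. It differs from compound 2 in one place: 2-chlorophenyl in place of 4-fluorophenyl on an amide-type nitrogen. For the measured compounds named here, this is the same group that compound 1 carries, though compound 1 and compound 3 also differ elsewhere, so no measured pair isolates this single change. Since compound 1 with 490 nM and compound 2 with 500 nM read alike, no step beyond the scatter is expected in this assay.

Compound 3 is expected to give 480 nM, within a range from 240 nM to 960 nM. That amounts to an expected step of a 1.0-fold lower number from compound 2 to compound 3 (0.02 log units; within the scatter).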

Compound 3, half-maximal inhibitory concentration: 460 nM
Beside the measured number, compound 3's estimate is 1.0-fold (0.02 log units) above it, within the range that was stated.
By their numbers in this assay, from the lowest: compounds 3, 1 and 2 (each within the scatter of the next).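

In this assay, 2-chlorophenyl in place of 4-fluorophenyl on the amide-type nitrogen gives a 1.1-fold lower number from compound 2 to compound 3 (0.04 log units; within the scatter) so this single change leaves the two compounds reading alike. Compound 3 also isolates a change in the chain, where diethylamino in place of (dimethylamino)methyl gives a 1.1-fold lower number from compound 1 to compound 3 (0.03 log units; within the scatter) and again the two compounds read alike, so neither change, taken alone, separates the compounds in this cell assay. No measurement at hand speaks to why these numbers stay together.

The change on the amide-type nitrogen swaps both the halogen and where it sits, so a compound with 4-chlorophenyl would be needed to tell those two apart. From the compounds shown here alone, whether a more different group, such as a carboxylic acid on the phenyl ring or a morpholine in place of diethylamino, would move the number also remains open.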